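The source may report more compounds than this note shows. Statements on the series, on what has been measured and on what is new or still open speak of the compounds shown alone.

Measured so far:
Compound 1 `O=c1[nH]c(Nc2cccc(F)c2)nc2cc(Cl)ccc12` gives > 25000 nM in an ADME assay on Vero cells (Chlorocebus sabaeus) for cytotoxicity, read by WST assay; a lower number here means that less compound is tolerated, a higher number that more compound is tolerated; this value is a limit of the assay, not a number.
Compound 2 `O=c1[nH]c(Nc2cc(F)cc(F)c2)nc2cc(Cl)ccc12` gives >= 18000 nM in this assay; this too is a limit, not a number.
Compound 3 `O=c1[nH]c(Nc2cc(Cl)cc(Cl)c2)nc2cc(Cl)ccc12` gives > 25000 nM in this assay; again a limit, not a number.

Compound 1 therefore has no exact value, only a limit. It sits at the limit of > 25000 nM in this assay, at which 2 of the 3 values shown sit, while the remaining value sits at the limit of >= 18000 nM in this assay, at which 1 of the 3 values shown sits. The one step among these compounds that changes a single place, a step that the two limits leave unreadable from compound 1 to compound 2, cannot be sized: both of its ends are limits.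

Compound 4 `COC(=O)c1cccc(Nc2nc3cc(Cl)ccc3c(=O)[nH]2)c1` has not yet been measured in this assay. It differs from compound 1 by methoxycarbonyl in place of fluoro on an aromatic carbon. Among the measured compounds shown here, no measured step exchanges a fluoro for a methoxycarbonyl; the only measured step is a fluoro-for-hydrogen exchange whose size the two limits hide. Nothing in the measured steps points to a readable move in either direction. The expectation for compound 4 is that it behaves like the three measured compounds and again reaches the limit, so the estimated step of a number no higher from compound 1 to compound 4 (the limit leaves the size open) is expected to be none beyond the scatter. The estimate for compound 4 is 25000 nM, with a range from 12000 nM to 50000 nM.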

Compound 4, half-maximal cytotoxic concentration: > 25000 nM
Compound 4: a limit, no number; the forecaster's own chance of this, stated with the estimate: 80%; the middle value lies on the limit itself.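

In this assay compound 4 gives > 25000 nM, which is a limit of the assay and not a number. Compound 1 also has only a limit, so the step between compound 1 and compound 4 cannot be read. The compounds shown leave open at what concentration each one harms the cells, and whether methoxycarbonyl in place of fluoro changes this at all.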